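The compounds below may be only part of what the source reports. "The series", "measured", "known", "first", "only" and "open" are said of these compounds alone.

Measured in a functional assay on MCF7 cells (Homo sapiens) for antiproliferative activity, read by MTT assay, with a stated time of 24 h; a higher number here means a weaker inhibitor, a lower number a stronger inhibitor:
- compound 1 `CCn1c(C(=O)N[C@H](C)C(=O)OC)ccc1C(CC)(CC)c1ccc(OCS(=O)(=O)c2ccccc2)c(C)c1`: > 50000 nM (a limit)
- compound 2 `CCn1c(C(=O)NCCN)ccc1C(CC)(CC)c1ccc(OCS(=O)(=O)c2ccccc2)c(C)c1`: 6470 nM
- compound 3 `CCN(CC)CCNC(=O)c1ccc(C(CC)(CC)c2ccc(OCS(=O)(=O)c3ccccc3)c(C)c2)n1CC`: 4680 nM

Among the measured compounds shown here, compound 3 cannot be separated from the only other compound with a numeric value: a 1.4-fold lower number from compound 2 to compound 3 (0.14 log units; within the scatter). The result for compound 1 is a limit and not a number.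

Compound 4 `CCn1c(C(=O)N[C@@H](C)CO)ccc1C(CC)(CC)c1ccc(OCS(=O)(=O)c2ccccc2)c(C)c1` is the next compound to consider against compound 3. It has 1-(hydroxymethyl)ethyl in place of 2-(diethylamino)ethyl on an amide-type nitrogen. Neither this group nor the 1-(methoxycarbonyl)ethyl of compound 1 contains the amino group found on the chains of compound 2 and compound 3.

For the measured compounds named here, two measured steps bear on the change: an at least 7.7-fold lower number from compound 1 to compound 2 (0.88 log units; beyond the scatter) and an at least 10-fold lower number from compound 1 to compound 3 (1.02 log units; beyond the scatter). Both lie beyond the scatter, and both start from a limit, so their true sizes are not known. Neither step involves 1-(hydroxymethyl)ethyl, so the comparison is only approximate. A step of similar size in the opposite direction is therefore expected in this assay, towards a higher number, though probably a somewhat smaller one.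

The expected change is a 4.7-fold higher number from compound 3 to compound 4 (0.67 log units; beyond the scatter). For compound 4 the estimated value is 22000 nM, with an expected range of 7000 nM to 50000 nM.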

Compound 4, half-maximal inhibitory concentration: 10800 nM
Compound 4: middle estimate off by 2.0-fold (0.31 log units), on the high side, within the range that was stated.
By their numbers in this assay, from the lowest: compounds 3, 2 and 4 (each within the scatter of the next, the first and the last beyond it). At a limit, above all of these: compound 1.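

In this assay a chain with no amino group still gives a numeric value, as 1-(hydroxymethyl)ethyl in place of 1-(methoxycarbonyl)ethyl on the amide-type nitrogen gives an at least 4.6-fold lower number from compound 1 to compound 4 (0.66 log units; beyond the scatter) and so an amino group on this chain is not needed to bring the series below the limit of compound 1. The amino-bearing chains do not behave as one group against compound 4: the change from 2-(diethylamino)ethyl gives a 2.3-fold higher number from compound 3 to compound 4 (0.36 log units; beyond the scatter) while the change from 2-aminoethyl gives a 1.7-fold higher number from compound 2 to compound 4 (0.22 log units; within the scatter) and only the first of these separates the pair. The result for compound 1 remains a limit and not a number, so the true size of its step is unknown: the limit of > 50000 nM in this assay, at which 1 of the 4 values shown sits.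

Open, on these data alone, is whether a carboxylic acid in place of the methyl ester of compound 1, or a longer hydroxyalkyl chain such as 3-hydroxypropyl, would read with compound 4 or with compound 1. Also open is what the defined stereocentre of 1-(hydroxymethyl)ethyl contributes, since its mirror-image form and the unbranched 2-hydroxyethyl chain are not among the compounds shown.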